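Half-life Unchanged Across Three Amide Variants

The source may report more compounds than this note shows. Statements on the series, on what has been measured and on what is new or still open speak of the compounds shown alone.

Compound 1 `C=CC(=O)N1CC(NC(=O)Cn2cc(C(=O)N3CCc4c(Cl)cccc4C3)c3cc(Br)ccc32)C1`: 1.67 h
Compound 2 `C=CC(=O)N1CC(NC(=O)Cn2cc(C(=O)NCc3ccccc3)c3cc(Br)ccc32)C1`: 1.67 h
Compound 3 `C=CC(=O)N1CC(NC(=O)Cn2ccc3cc(Br)ccc32)C1`: 1.67 h

In a physicochemical assay for pharmacokinetics, read by LC-MS, in phosphate buffer, at pH 7.4, in the presence of a further agent that is not named here (on this read-out lower numbers stand for a shorter-lived compound and higher numbers for a longer-lived compound), compound 2 gives 1.67 h, level with compound 1 and compound 3 at the digits shown. The step from compound 1 to compound 2 was no change at the digits printed from compound 1 to compound 2 (within the scatter), and the step from compound 2 to compound 3 was no change at the digits printed from compound 2 to compound 3 (within the scatter). Compound 4 `C=CC(=O)N1CC(NC(=O)Cn2cc(C(=O)N3CCc4c(cccc4OC)C3)c3cc(Br)ccc32)C1` differs from compound 2 in that (a group of 12 heavy atoms (10 carbon, 1 nitrogen, 1 oxygen; one six-membered non-aromatic ring with 1 hetero atom, one six-membered aromatic ring of carbon only) in place of a group of 8 heavy atoms (7 carbon, 1 nitrogen; one six-membered aromatic ring of carbon only), on a carbonyl carbon). The step from compound 1 to compound 2, which also exchanged a bicyclic amide group for benzylamino, bears most directly on this change and showed nothing beyond the scatter. Compound 4 is therefore expected to show no change at the digits printed from compound 2 to compound 4 (within the scatter), no step beyond the scatter, and its estimated value in this assay is 1.67 h, within 0.9 h to 3.2 h.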

Compound 4, half-life: 1.67 h
Beside the measured number, compound 4's estimate shows no gap at the digits printed; the range from low to high includes it.
By their numbers in this assay, from the lowest: compounds 1, 2, 3 and 4 (each within the scatter of the next).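

In this assay, the group of 12 heavy atoms in place of benzylamino on the carbonyl carbon gave no change at the digits printed from compound 2 to compound 4 (within the scatter), although this group has no hydrogen-bond donor and benzylamino has one. Methoxy in place of chloro on an aromatic carbon, a change the earlier compounds did not include, gave no change at the digits printed from compound 1 to compound 4 (within the scatter). Nothing available explains why these values stay level.

From the compounds shown here alone, whether an amine or a carboxylic acid in place of methoxy would shift the half-life remains open. With all four values level, it is also unknown whether any change at these places can move this read-out.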